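Halogen swap on the aryl ring: third pair in the series

This account rests on a few compounds, and the source may have more. Where it says the series, first, only, none or still open, it means among the compounds named here.

Measured compounds:
Compound 1 `COc1cc2c(Oc3ccc(NC(=O)c4nn(-c5ccccc5F)c(=O)c5ccccc45)cc3F)ccnc2cc1OCCCN1CCCC1` gives 230 nM in a functional assay on NCI-H460 cells (Homo sapiens) for cytotoxicity, read by MTT assay, with a stated time of 72 h; a higher number here means a weaker inhibitor, a lower number a stronger inhibitor.
Compound 2 `COc1cc2c(Oc3ccc(NC(=O)c4nn(-c5ccc(Br)cc5)c(=O)c5ccccc45)cc3F)ccnc2cc1OCCCN1CCCC1` gives 180 nM in this assay.
Compound 3 `COc1cc2c(Oc3ccc(NC(=O)c4nn(-c5ccccc5F)c(=O)c5ccccc45)cc3F)ccnc2cc1OCCCN1CCCCC1` gives 160 nM in this assay.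

Compound 4 `COc1cc2c(Oc3ccc(NC(=O)c4nn(-c5ccc(Br)cc5)c(=O)c5ccccc45)cc3F)ccnc2cc1OCCCN1CCCCC1` has not yet been run in this assay.

The change from compound 3 to compound 4 is 4-bromophenyl in place of 2-fluorophenyl on an aromatic nitrogen. The same change has been made once already, from compound 1 to compound 2, where it reads 4-bromophenyl in place of 2-fluorophenyl on an aromatic nitrogen and gave a 1.3-fold lower number from compound 1 to compound 2 (0.11 log units; within the scatter). The two place lines agree word for word, so this counts as the same change on a different core. The cores differ by piperidin-1-yl in place of pyrrolidin-1-yl on a saturated chain carbon, three bonds along the chain from an oxygen on an aromatic ring, a difference that on its own gave a 1.4-fold lower number from compound 1 to compound 3 (0.16 log units; within the scatter).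

With one prior occurrence only, the expectation for compound 4 rests on that single pair. The step of a 1.3-fold lower number from compound 3 to compound 4 (0.11 log units; within the scatter) is expected to be about the size of a 1.3-fold lower number from compound 1 to compound 2 (0.11 log units; within the scatter), and the outcome is expected to stay within scatter of compound 3 because a 1.3-fold lower number from compound 1 to compound 2 (0.11 log units; within the scatter) itself was within scatter. Compound 4 is estimated at 125 nM, with a range from 60 nM to 260 nM.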

Compound 4, half-maximal inhibitory concentration: 410 nM
Compound 4: middle estimate off by 3.3-fold (0.52 log units), on the low side, and the stated range ends below it.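

In this assay, 4-bromophenyl in place of 2-fluorophenyl does not carry from the core of compound 1 to the core of compound 3, with the new step reading a 2.6-fold higher number from compound 3 to compound 4 (0.41 log units; beyond the scatter) and differing from the earlier one: the same change on two cores in this assay, a 1.3-fold lower number (0.11 log units; within the scatter) from compound 1 to compound 2 and a 2.6-fold higher number (0.41 log units; beyond the scatter) from compound 3 to compound 4, 3.3-fold (0.52 log units) apart, beyond the scatter of two such steps

Read the other way, piperidin-1-yl in place of pyrrolidin-1-yl also depends on the aryl group, giving a 2.3-fold higher number from compound 2 to compound 4 (0.36 log units; beyond the scatter), so the two changes do not add across these four compounds: the same change on two cores in this assay, a 1.4-fold lower number (0.16 log units; within the scatter) from compound 1 to compound 3 and a 2.3-fold higher number (0.36 log units; beyond the scatter) from compound 2 to compound 4, 3.3-fold (0.52 log units) apart, beyond the scatter of two such steps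

Both comparisons rest on the same four compounds and so count as one observation; they show that the step from one change cannot be transferred here, but not why, nor whether this holds beyond this set.

The swap alters both the halogen and its place on the phenyl ring, and the compounds shown do not separate the two. A 4-fluorophenyl or 2-bromophenyl group on both cores would bear on this, while a morpholin-4-yl group on the chain would test whether the dependence extends to another amine.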